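Sulfonamide Substituent Swap Expected to Weaken Nek1 Inhibition

This account rests on a few compounds, and the source may have more. Where it says the series, first, only, none or still open, it means among the compounds named here.

Of the compounds shown here, two built on one shared core have been tested in an assay on isolated protein for inhibition of serine/threonine-protein kinase Nek1 (Homo sapiens), read by TR-FRET, with a stated time of 30 min; on this read-out higher numbers stand for weaker inhibition and lower numbers for stronger inhibition. Compound 1 `COCCNS(=O)(=O)c1ccc(-c2ccnc3[nH]ccc23)cc1` carries a (2-methoxyethyl)amino group on its sulfonyl sulfur; in this assay compound 1 reaches only the limit of the test, > 30000 nM. Within the data shown here, compound 2 `CN(CCO)S(=O)(=O)c1ccc(-c2ccnc3[nH]ccc23)cc1` carries a (2-hydroxyethyl)(methyl)amino group instead, and in this assay compound 2 gives 2700 nM, the only true number among the two results. Among the measured compounds shown here, the step of an at least 11-fold lower number from compound 1 to compound 2 (1.04 log units; beyond the scatter) is the single measured comparison, and its full extent is unknown since it rests on (the limit of > 30000 nM in this assay, at which 1 of the 2 values shown sits).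

Compound 3 `CC(=O)OCCNS(=O)(=O)c1ccc(-c2ccnc3[nH]ccc23)cc1` is not yet measured. It differs from compound 2 by (2-acetoxyethyl)amino in place of (2-hydroxyethyl)(methyl)amino on a sulfonyl sulfur. This change removes the methyl from the nitrogen, as in compound 1, and converts the free hydroxyl into an ester. For the measured compounds named here, because the only measured step of an at least 11-fold lower number from compound 1 to compound 2 (1.04 log units; beyond the scatter) ran in the opposite direction, a weakening step a 7.4-fold higher number from compound 2 to compound 3 (0.87 log units; beyond the scatter) is expected. Compound 3 is therefore estimated at 20000 nM in this assay, with a likely range from 5000 nM to 60000 nM, and a real chance that only a limit is reported.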

Compound 3, half-maximal inhibitory concentration: 8800 nM
Compound 3: the middle estimate sits 2.3-fold (0.36 log units) above what was measured; the measured number falls inside the stated range.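

With acetyl in place of methyl on the oxygen, the side chain on the sulfonyl sulfur gives an at least 3.4-fold lower number from compound 1 to compound 3 (0.53 log units; beyond the scatter) in this assay, so a group with no methyl on its nitrogen can still give a true number at this position, which compound 1 alone did not show. Set against compound 2, the (2-acetoxyethyl)amino group gives a 3.3-fold higher number from compound 2 to compound 3 (0.51 log units; beyond the scatter), which leaves compound 2 the strongest inhibitor of the three, although this swap alters both the nitrogen and the end of the chain, so the two alterations cannot be told apart. The step from compound 1 gives only a minimum size, and its full extent is unknown, since it rests on a limit: the limit of > 30000 nM in this assay, at which 1 of the 3 values shown sits.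

On these data alone, it remains open whether a plain (2-hydroxyethyl)amino group, or a (2-methoxyethyl)(methyl)amino group, would fall nearer to compound 2 or to compound 1, and so whether the methyl on the nitrogen or the free hydroxyl matters more. As far as these compounds go, how a longer chain, or a chain ending in an amine or a carboxylic acid, would behave on the sulfonyl sulfur is also open.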